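This account rests on a few compounds, and the source may have more. Where it says the series, first, only, none or still open, it means among the compounds named here.

Measured compounds in a functional assay on MCF7 cells (Homo sapiens) for cytotoxicity, read by MTT assay, with a stated time of 48 h; a higher number here means a weaker inhibitor, a lower number a stronger inhibitor:
- compound 1 `C/C(=N\NC(=S)Nc1ccccc1[N+](=O)[O-])c1ccccn1` gives 5.7 nM
- compound 2 `C/C(=N/NC(=S)Nc1ccccc1[N+](=O)[O-])c1ccccn1` gives 5.7 nM
- compound 3 `CC(=NNC(=S)Nc1ccccc1[N+](=O)[O-])c1ccccn1` gives 5.7 nM

Compound 1 stands level with compounds 2 and 3. The steps of no change at the digits printed from compound 1 to compound 2 (within the scatter) and no change at the digits printed from compound 1 to compound 3 (within the scatter) hold no change, which follows from the fact that compounds 1 and 2 differ only in the configuration as drawn and the fact that one of compounds 1 and 3 is drawn with a defined configuration and the other without, at the place where they differ: the three compounds share the same atoms and bonds and differ only in how the double bond is drawn.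

Compound 4 `C/C(=N\NC(=S)Nc1ccccc1Cl)c1ccccn1` is not yet measured. It differs from compound 1 by chloro in place of nitro on an aromatic carbon. Within the data shown here, none of the measured steps touches this position, so they give no guide to direction or size; the change is a real change of substituent, unlike the steps measured so far. The estimate for compound 4 is 12 nM, between 2.5 nM and 60 nM, a step of a 2.1-fold higher number from compound 1 to compound 4 (0.32 log units; beyond the scatter) expected from compound 1.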

Compound 4, half-maximal inhibitory concentration: 0.16 nM
Compound 4: the middle estimate sits 75-fold (1.88 log units) above what was measured, and the stated range ends above it.
By their numbers in this assay, from the lowest: compound 4; then compounds 1, 2 and 3 (each within the scatter of the next).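

The earlier compounds shown here differ only in how a double bond is drawn, whereas here the substituent itself changes: in this assay, chloro in place of nitro brings a 36-fold lower number from compound 1 to compound 4 (1.55 log units; beyond the scatter). This shows that the number responds strongly to the group on this aromatic carbon, ortho to a large group. Nothing available explains why it falls so far.

As far as these compounds go, whether chloro is unusual here stays open, since an amine, a methyl group or a methoxy group at this place could show how far the trend extends.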